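Swapping the five-membered ring on the biphenyl-like tail

The compounds below may be only part of what the source reports. "The series", "measured", "known", "first", "only" and "open" are said of these compounds alone.

Measured so far:
compound 1, `CCC(C)(C)Cc1c[nH]c(CCc2ccc(-c3ccncc3)cc2)n1`: 103 nM
compound 2, `CCC(C)(C)Cc1c[nH]c(CCc2ccc(-c3csnn3)cc2)n1`: 109 nM

Compound 1 and compound 2 share one core and differ only in the ring attached to the aromatic carbon. In a functional assay on HEK293 cells for agonist activity at Bombesin receptor subtype-3 (Mus musculus), read by luminescence and calcium flux, with a stated time of 10 min (on this read-out higher numbers stand for an effect only at larger amounts of compound and lower numbers for an effect already at smaller amounts), compound 1 gives 103 nM and compound 2 gives 109 nM. For the measured compounds named here, the one step measured, a 1.1-fold higher number from compound 1 to compound 2 (0.02 log units; within the scatter), is within the scatter. Among the two numbers compound 2 stands highest, but its gap to compound 1 is within the scatter, so no order can be read from it.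

Compound 3, `CCC(C)(C)Cc1c[nH]c(CCc2ccc(-c3ccns3)cc2)n1`, is not yet measured. It differs from compound 2 by 1,2-thiazol-5-yl in place of 1,2,3-thiadiazol-4-yl on an aromatic carbon. Going by the values given here, the only step that bears on this is the within-scatter one from compound 1 to compound 2, where a different ring at the same place changed little; therefore no step beyond the scatter is expected in this assay. Compound 3 is expected to give 110 nM, within 50 nM to 250 nM, which means an expected step of a 1.0-fold higher number from compound 2 to compound 3 (0.00 log units; within the scatter).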

Compound 3, half-maximal effective concentration: 103 nM
Compound 3: middle estimate off by 1.1-fold (0.03 log units), on the high side, and the stated range covers the measured number.
By their numbers in this assay, from the lowest: compounds 1, 3 and 2 (each within the scatter of the next).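

In this assay, the change to 1,2-thiazol-5-yl gives a 1.1-fold lower number from compound 2 to compound 3 (0.02 log units; within the scatter), while the comparison with the six-membered ring gives no change at the digits printed from compound 1 to compound 3 (within the scatter). This place, on an aromatic carbon para to a large group, now holds pyridin-4-yl and two five-membered aromatic rings, all within the scatter of one another, and the drop from 3 to 2 hydrogen-bond acceptors between the two five-membered rings goes with no readable shift in the numbers. No measurement at hand explains why these rings give such similar numbers.

Going by these compounds, all three compounds carry an aromatic ring at this place, so it remains open whether a carboxylic acid, a primary amine or a plain alkyl chain would be tolerated there. On these data alone, it also remains open whether the same insensitivity would hold with changes elsewhere on the shared core.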